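The source may report more compounds than this note shows. Statements on the series, on what has been measured and on what is new or still open speak of the compounds shown alone.

In a functional assay on KB cells (Homo sapiens) for antiproliferative activity, read by MTT assay, with a stated time of 72 h (on this read-out lower numbers stand for stronger inhibition and higher numbers for weaker inhibition), compound 3 `COc1ccc(-c2c(-c3cc(OC)c(OC)c(OC)c3)ssc2=O)cc1` gives only a limit, > 100000 nM, and no number. Two related compounds do give numbers in the same test: compound 1 `COc1ccc(-c2c(-c3cc(OC)c(OC)c(OC)c3)ssc2=S)cc1` reaches 1140 nM, and compound 2 `COc1ccc(-c2ssc(=O)c2-c2cc(OC)c(OC)c(OC)c2)cc1[N+](=O)[O-]` reaches 22300 nM.

Compound 4 `COc1ccc(-c2c(-c3cc(OC)c(OC)c(OC)c3)ssc2=O)cc1[N+](=O)[O-]` has not yet been measured. It comes from compound 3 by placing nitro in place of hydrogen on an aromatic carbon, ortho to a methoxy group and meta to a large group (nitro in place of hydrogen on an aromatic carbon).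

Among the measured compounds shown here, no measured pair shows this change directly, so the expectation rests on thin ground. Compound 2 also carries a nitro group and has a measurable value of 22300 nM, which suggests that compound 4 may also give a number in this assay. A step toward stronger inhibition is therefore expected, though its size stays uncertain while compound 3 has no number. The expected change is an at least 5.0-fold lower number from compound 3 to compound 4 (0.69 log units; beyond the scatter). For compound 4 the estimated value is 20000 nM, with an expected range from 4000 nM to 100000 nM.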

Compound 4, half-maximal inhibitory concentration: > 100000 nM
Compound 4: a limit, no number; the forecaster's own chance of this, stated with the estimate: 25%; at least 5.0-fold (0.69 log units) between middle value and limit.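

Compound 3 and compound 4 both give only a limit in this assay, so no step can be read from compound 3 to compound 4: the limit of > 100000 nM in this assay, at which 2 of the 4 values shown sit.

The compounds shown leave open whether nitro in place of hydrogen on an aromatic carbon changes inhibition at all, and in which direction.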